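Pyrimidin-5-yl for furan-3-yl: expected solubility of compound 4

This account rests on a few compounds, and the source may have more. Where it says the series, first, only, none or still open, it means among the compounds named here.

Measured compounds in a physicochemical assay for solubility, in phosphate buffer, with a stated time of 18 h, at pH 7; on this read-out higher numbers stand for higher solubility and lower numbers for lower solubility:
- compound 1, `CC(C)CN1C(=O)c2ccccc2[C@H](C(=O)Nc2ccc(F)c(C#N)c2)[C@H]1c1ccoc1`, gives 15000 nM
- compound 2, `CC(C)CN1C(=O)c2ccccc2[C@H](C(=O)Nc2ccc(F)c(C#N)c2)[C@H]1c1ccc(C(N)=O)s1`, gives 19000 nM
- compound 3, `CC(C)CN1C(=O)c2ccccc2[C@H](C(=O)Nc2ccc(F)c(C#N)c2)[C@H]1c1cccnc1`, gives 55000 nM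

Compound 1 holds the lowest of the three numbers in this assay. Its nearest neighbour is compound 2, and the step of a 1.3-fold higher number from compound 1 to compound 2 (0.10 log units; within the scatter) is within the scatter. The furthest is compound 3, and the step of a 3.7-fold higher number from compound 1 to compound 3 (0.56 log units; beyond the scatter) is beyond the scatter, though modest.

Compound 4, `CC(C)CN1C(=O)c2ccccc2[C@H](C(=O)Nc2ccc(F)c(C#N)c2)[C@H]1c1cncnc1`, has not yet been measured in this assay. It differs from compound 1 in one place: pyrimidin-5-yl in place of furan-3-yl on a saturated ring carbon.

Going by the values given here, the step that bears most on this change is the one from compound 1 to compound 3, where a six-membered aromatic ring with one nitrogen replaced furan-3-yl on the same saturated ring carbon and a 3.7-fold higher number from compound 1 to compound 3 (0.56 log units; beyond the scatter) resulted. The step to compound 2, a 1.3-fold higher number from compound 1 to compound 2 (0.10 log units; within the scatter), shows that not every replacement of furan-3-yl moves the number. Pyrimidin-5-yl is a six-membered aromatic ring with two hetero atoms, closer in kind to pyridin-3-yl than to the groups in compound 1 or compound 2, so a modest rise beyond the scatter is expected.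

Compound 4 is therefore estimated at 60000 nM, with a range from 25000 nM to 150000 nM, which is expected to mean a step of a 4.0-fold higher number from compound 1 to compound 4 (0.60 log units; beyond the scatter).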

Compound 4, solubility: 54000 nM
Compound 4: middle estimate off by 1.1-fold (0.05 log units), on the high side; low and high end bracket the measured number.
By their numbers in this assay, from the lowest: compounds 1 and 2 (each within the scatter of the next); then compounds 4 and 3 (each within the scatter of the next).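

On this saturated ring carbon, pyrimidin-5-yl in this assay joins pyridin-3-yl in standing apart from furan-3-yl (a 3.6-fold higher number from compound 1 to compound 4 (0.56 log units; beyond the scatter)), so the rise seen with compound 3 is no longer a single case. The two six-membered aromatic rings cannot be told apart in this read-out (a 1.0-fold lower number from compound 3 to compound 4 (0.01 log units; within the scatter)), and the extra ring nitrogen of compound 4 brings no change that can be seen beyond the scatter, while compound 4, like compound 3, also stands apart from the 5-carbamoylthiophen-2-yl compound (a 2.8-fold higher number from compound 2 to compound 4 (0.45 log units; beyond the scatter)). No measurement shown here explains why these rings group as they do.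

As far as these compounds go, whether a plain phenyl ring, with no ring nitrogen, would fall with compounds 3 and 4 or with compounds 1 and 2 stays open, so ring size and ring nitrogen remain unseparated in these compounds. Also open, from the compounds shown here alone, is whether the grouping would hold with a longer chain or a chain ending in a carboxylic acid in place of the isobutyl group, which all four compounds carry.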